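Aryl hydrazone variation in the triazolylpyridine urea series

A few compounds are considered here, and "the series" means these few. Any claim that something is new, unique, unknown or untested is made for them only; others in the source may bear on it.

In a functional assay on U-87MG ATCC cells (Homo sapiens) for cytotoxicity, read by MTT assay, with a stated time of 72 h (on this read-out lower numbers stand for stronger inhibition and higher numbers for weaker inhibition), compound 3 `CN(C)CCn1cnnc1-c1cc(Oc2ccc(NC(=O)N/N=C/c3cccc(Br)c3)cc2F)ccn1` gives 830 nM, the lowest of the three numbers measured. Compound 1 `COc1cc(/C=N/NC(=O)Nc2ccc(Oc3ccnc(-c4nncn4CCN(C)C)c3)c(F)c2)cc(OC)c1OC` gives 22500 nM and compound 2 `CN(C)CCn1cnnc1-c1cc(Oc2ccc(NC(=O)N/N=C/c3cccc(Cl)c3Cl)cc2F)ccn1` gives 13200 nM. The step of a 27-fold lower number from compound 1 to compound 3 (1.43 log units; beyond the scatter) and the step of a 16-fold lower number from compound 2 to compound 3 (1.20 log units; beyond the scatter) are both large, while a 1.7-fold lower number from compound 1 to compound 2 (0.23 log units; within the scatter) stays within the scatter. Compound 4 `COc1cc(/C=N/NC(=O)Nc2ccc(Oc3ccnc(-c4nncn4CCN(C)C)c3)c(F)c2)ccc1O` differs from compound 3 by 4-hydroxy-3-methoxyphenyl in place of 3-bromophenyl on a carbon with a double bond to nitrogen. The step from compound 1 to compound 3 bears most directly on this change, since the 3,4,5-trimethoxyphenyl of compound 1 gives 22500 nM and the entering ring shares its oxygen substitution. A large rise in number toward compound 1 is therefore expected, with an 11-fold higher number from compound 3 to compound 4 (1.04 log units; beyond the scatter) as the estimated step. Compound 4 is expected at 9000 nM, within 2500 nM to 35000 nM.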

Compound 4, half-maximal inhibitory concentration: > 100000 nM
Compound 4 ended at the assay's limit (the forecaster's own chance of this, stated with the estimate: 10%); middle value at least 11-fold (1.04 log units) from the limit.
By their numbers in this assay, from the lowest: compound 3; then compounds 2 and 1 (each within the scatter of the next). At a limit, above all of these: compound 4.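

Compound 4 stands at a limit of this assay, not at a number: the limit of > 100000 nM in this assay, at which 1 of the 4 values shown sits. The 4-hydroxy-3-methoxyphenyl ring gives the largest step yet seen on this carbon with a double bond to nitrogen, with an at least 120-fold higher number from compound 3 to compound 4 (2.08 log units; beyond the scatter). It also stands apart from the two rings that lay within the scatter of each other, with an at least 7.5-fold higher number from compound 2 to compound 4 (0.87 log units; beyond the scatter) and an at least 4.4-fold higher number from compound 1 to compound 4 (0.64 log units; beyond the scatter), so the two oxygen-bearing rings do not read alike here.

The compounds shown do not separate the hydroxyl of compound 4 from its methoxy, so a 4-hydroxyphenyl or a 3-methoxyphenyl ring remains an open comparison. Going by these compounds, whether the value of compound 3 belongs to bromine itself or carries over to a 3-chlorophenyl ring also stays open.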